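The compounds below may be only part of what the source reports. "The series", "measured", "known", "first", "only" and "open" are said of these compounds alone.

For the measured compounds named here, in a functional assay on the whole organism (strain Sprague-Dawley) for inhibition, with Rattus norvegicus as the target, with a stated time of 10 min (a higher number here means that more compound is needed for the effect, a lower number that less compound is needed), compound 3 `CCCOc1ccccc1-c1ncc(C(=O)OCC)c(=O)[nH]1` gives 5 mg/kg, the only actual number so far. Compound 1 `CCOC(=O)c1cnc(-c2ccccc2F)[nH]c1=O` gives > 10 mg/kg, which is a limit of the assay and not a number. For compound 2 `CCOC(=O)c1cnc(-c2ccccc2N)[nH]c1=O` the entry reads "not determined" (no result reported). Compound 4 `CCCCCOc1ccccc1-c1ncc(C(=O)OCC)c(=O)[nH]1` lengthens the propyl of compound 3 to pentyl: ethyl in place of hydrogen on a saturated chain carbon, three bonds along the chain from an oxygen on an aromatic ring. Going by the values given here, the only measured step, an at least 2.0-fold lower number from compound 1 to compound 3 (0.30 log units; that floor lies within the scatter), swaps fluoro for propoxy at a different place and gives no direct reading on chain length. No step beyond the scatter is therefore expected in this assay, in either direction. The expected step is a 1.2-fold higher number from compound 3 to compound 4 (0.08 log units; within the scatter). For compound 4 the estimated value is 6 mg/kg, with an expected range of 2 mg/kg to 15 mg/kg.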

Compound 4, dose for 50% inhibition: 2 mg/kg
For compound 4 the middle estimate is 3.0-fold (0.48 log units) above the measured one; the measured number falls inside the stated range.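

Lengthening the chain on the oxygen from propyl to pentyl registers in this assay: a 2.5-fold lower number from compound 3 to compound 4 (0.40 log units; beyond the scatter), the first step in chain length and one read between two actual numbers. Replacing fluoro with pentyloxy gives an at least 5.0-fold lower number from compound 1 to compound 4 (0.69 log units; beyond the scatter), whereas the floor for propoxy stayed within the scatter. Compound 1 stands at a limit, so this step is a floor only: the limit of > 10 mg/kg in this assay, at which 1 of the 4 values shown sits.

Two chain lengths establish no trend. Going by these compounds, whether a longer chain such as heptyl, a branched chain, or a chain ending in an amine would lower the number further remains open.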